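The source may hold more compounds than are shown below. What is called first, only, known or untested is meant among the compounds shown, and "the series" means these compounds.

Working notes on the series. For the measured compounds named here, compound 3 `COc1ccc(NC(=O)Nc2nc(Sc3c[nH]c4ccccc34)cc(N3CCCC3)n2)cc1` in a functional assay on A549 cells (Homo sapiens) for inhibition, with a stated time of 72 h (a lower number here means a stronger inhibitor, a higher number a weaker inhibitor), gives 11800 nM, the smaller of the two numbered values so far. Compound 1 `COc1ccc(NC(=O)Nc2nc(Sc3c[nH]c4ccccc34)cc(N3CCCCC3)n2)cc1` in this assay gives 13500 nM, and the gap a 1.1-fold lower number from compound 1 to compound 3 (0.06 log units; within the scatter) is within the scatter. Compound 2 `COc1ccc(NC(=O)Nc2nc(Nc3cc(OC)cc(OC)c3)cc(Sc3c[nH]c4ccccc34)n2)cc1` in this assay sits at the limit > 50000 nM, a limit of the assay rather than a number (the limit of > 50000 nM in this assay, at which 1 of the 3 values shown sits). The steps of an at least 3.7-fold higher number from compound 1 to compound 2 (0.56 log units; beyond the scatter) and an at least 4.2-fold lower number from compound 2 to compound 3 (0.62 log units; beyond the scatter) are both beyond the scatter, but they vary the group on the aromatic carbon of the core, not the part changed here.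

Compound 4 `Cc1cc(Cl)ccc1NC(=O)Nc1nc(Sc2c[nH]c3ccccc23)cc(N2CCCC2)n1` differs from compound 3 by 4-chloro-2-methylphenyl in place of 4-methoxyphenyl on an amide-type nitrogen. Going by the values given here, no measured step touches this amide-type nitrogen, so nothing tells how the aryl on it moves the number. Among the compounds with values here, with no bearing step, the expectation in this assay is a step of no size beyond the scatter, a 1.0-fold higher number from compound 3 to compound 4 (0.01 log units; within the scatter), with wide uncertainty. Compound 4 is therefore estimated at 12000 nM, in the range 4000 nM to 36000 nM.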

Compound 4, half-maximal inhibitory concentration: 8930 nM
Compound 4: the middle estimate sits 1.3-fold (0.13 log units) above what was measured, and the stated range covers the measured number.
By their numbers in this assay, from the lowest: compounds 4, 3 and 1 (each within the scatter of the next). At a limit, above all of these: compound 2.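

The first change shown on the amide-type nitrogen gives, in this assay, a 1.3-fold lower number from compound 3 to compound 4 (0.12 log units; within the scatter). Compound 3 and compound 4 therefore cannot be told apart here, although 4-chloro-2-methylphenyl, unlike 4-methoxyphenyl, has no hydrogen-bond acceptor, so in this pair that acceptor is not needed to hold the number. No measured property shown bears on this result.

From the compounds shown here alone, this single pair does not separate the contribution of the chloro group from that of the methyl group, and it covers only compounds carrying pyrrolidin-1-yl on the core, so the same change alongside piperidin-1-yl remains open. Also open, going by these compounds, is whether a carboxylic acid or a primary amine on this aryl ring, or a longer alkyl chain in place of the ring, would move the number beyond the scatter.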